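Halogen at the fused benzo ring: chloro to bromo

The source may hold more compounds than are shown below. What is called first, only, known or untested is meant among the compounds shown, and "the series" means these compounds.

Measured so far in an assay for inhibition of high affinity nerve growth factor receptor (Homo sapiens), read by HTRF, with a stated time of 30 min, in the presence of a further agent that is not named here; on this read-out lower numbers stand for stronger inhibition and higher numbers for weaker inhibition:
compound 1 `Cc1cc(Nc2nc(NCc3ccc(F)cc3F)nc3ccccc23)n[nH]1` gives 200 nM
compound 2 `Cc1cc(Nc2nc(NCc3ccc(F)cc3F)nc3cc(F)ccc23)n[nH]1` gives 62 nM
compound 3 `Cc1cc(Nc2nc(NCc3ccc(F)cc3F)nc3cc(Cl)ccc23)n[nH]1` gives 15 nM

Compound 3 stands at the lowest number of the three. Its nearest neighbour is compound 2, and the difference a 4.1-fold lower number from compound 2 to compound 3 (0.62 log units; beyond the scatter) lies beyond the scatter; the gap to compound 1, a 13-fold lower number from compound 1 to compound 3 (1.12 log units; beyond the scatter), is larger still. The step from hydrogen to fluoro on the same ring, a 3.2-fold lower number from compound 1 to compound 2 (0.51 log units; beyond the scatter), was modest.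

Compound 4 `Cc1cc(Nc2nc(NCc3ccc(F)cc3F)nc3cc(Br)ccc23)n[nH]1` continues the halogen series at this position: bromo in place of chloro on an aromatic carbon. The bearing steps are those replacing hydrogen by fluoro, and fluoro by chloro, both of which lowered the number, and the whole run from hydrogen to chloro was large. Whether the trend carries on from chloro to bromo is not shown by any measured pair; a further lowering is possible but a number near that of compound 3 is equally plausible. The step of a 1.5-fold lower number from compound 3 to compound 4 (0.18 log units; within the scatter) is therefore expected to be small, at or just beyond the scatter, toward a lower number. For compound 4 the estimate in this assay is 10 nM, with a range of 4 nM to 25 nM.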

Compound 4, half-maximal inhibitory concentration: 53 nM
Compound 4: the middle estimate sits 5.3-fold (0.72 log units) below what was measured; the whole stated range lies below it.
By their numbers in this assay, from the lowest: compound 3; then compounds 4 and 2 (each within the scatter of the next); then compound 1.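

At this position the lowering of the number in this assay stops at chloro, and bromo in place of chloro turns it back (a 3.5-fold higher number from compound 3 to compound 4 (0.55 log units; beyond the scatter)), so the halogen series does not run in one direction: compound 3 keeps the lowest number of the four, with its steps to all the others beyond the scatter. Bromo still holds a gain over hydrogen (a 3.8-fold lower number from compound 1 to compound 4 (0.58 log units; beyond the scatter)), yet it does not separate from fluoro (a 1.2-fold lower number from compound 2 to compound 4 (0.07 log units; within the scatter)), a step within the scatter. Nothing available here accounts for the reversal from chloro to bromo.

Open, on these data alone, is whether a non-halogen group at this position, such as methyl, methoxy, nitrile or an amine, would match or pass chloro. Also open, as far as these compounds go, is whether the same halogen order holds on the other aromatic carbons of this ring.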